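The compounds below may be only part of what the source reports. "The series", "measured", "known", "first", "only" and "open" are said of these compounds alone.

Working notes on the series. Of the compounds shown here, three sharing one core have been measured in a functional assay on PANC-1 cells (Homo sapiens) for inhibition, read by MTT assay, with a stated time of 24 h, tested at 10 uM; on this read-out higher numbers stand for more inhibition at the one concentration tested (going by the name of the read-out) and lower numbers for less inhibition. Compound 1 `CC(C)=CCC1Cc2c(OCCCNS(=O)(=O)c3ccc(Cl)cc3)cc(=O)n(CCCO)c2CC1(C)C` gives 24.7%, compound 2 `CC(C)=CCC1Cc2c(OCCCNS(=O)(=O)c3ccc(Br)cc3)cc(=O)n(CCCO)c2CC1(C)C` gives 19.5%, and compound 3 `CC(C)=CCC1Cc2c(OCCCNC(=O)c3ccco3)cc(=O)n(CCCO)c2CC1(C)C` gives 2.1%. Compound 3 sits lowest of the three: the step of a number 22.6 percentage points lower from compound 1 to compound 3 (beyond the scatter) and the step of a number 17.4 percentage points lower from compound 2 to compound 3 (beyond the scatter) are both beyond the scatter, whereas the step of a number 5.2 percentage points lower from compound 1 to compound 2 (within the scatter) is within it.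

Compound 4 `CC(C)=CCC1Cc2c(OC(=O)Nc3cccc(F)c3)cc(=O)n(CCCO)c2CC1(C)C` is the next candidate. Relative to compound 3, the change is (3-fluorophenyl)carbamoyl in place of 3-(((furan-2-yl)carbonyl)amino)propyl on an oxygen on an aromatic ring. The two steps that reach compound 3, from compound 1 and from compound 2, each swapped only the group on the amine nitrogen while keeping the propyl chain, and each moved this assay by a modest amount. The change to compound 4 is of another kind: the whole chain with its amide leaves and a carbamoyl group with a 3-fluorophenyl ring attaches directly to the ring oxygen. Among the measured compounds shown here, no measured step mirrors this, so the measured steps give only weak guidance. An expectation of a moderate rise is taken, because compound 1 gave 24.7% with an aromatic ring in the side chain, with wide uncertainty. The expected step is a number 11.9 percentage points higher from compound 3 to compound 4 (beyond the scatter). Compound 4 is therefore estimated at 14%, within a range from 0% to 38%.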

Compound 4, a percentage reported as inhibition, at one concentration (the size of the read-out at that concentration, not a potency): 66.1%
The estimate for compound 4 lay 52.1 percentage points below the measured number; measured number above the stated range.
By their numbers in this assay, from the lowest: compound 3; then compounds 2 and 1 (each within the scatter of the next); then compound 4.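

The step of a number 64 percentage points higher from compound 3 to compound 4 (beyond the scatter) in this assay is large, and it is the first listed change made on the oxygen on an aromatic ring rather than on the amine nitrogen of the propyl chain. The read-out therefore responds strongly to the group on this oxygen, and the size of this step exceeds that of the modest exchanges on the amine nitrogen, a number 22.6 percentage points lower from compound 1 to compound 3 (beyond the scatter) and a number 17.4 percentage points lower from compound 2 to compound 3 (beyond the scatter). No supporting evidence bears on the origin of this rise.

The single change removes the propyl chain, the amide and the furan ring together while bringing in the carbamoyl link and the 3-fluorophenyl ring, so the compounds shown do not separate the contribution of each part. On these data alone, it remains open whether a phenylcarbamoyl group without the fluorine, a (furan-2-yl)carbamoyl group, or a 3-(3-fluorophenyl)propyl chain on the same oxygen would keep the number of compound 4 at 66.1%.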